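The source may report more compounds than this note shows. Statements on the series, on what has been measured and on what is new or still open speak of the compounds shown alone.

Three compounds were measured in an ADME assay on NHDF cells (Homo sapiens) for cytotoxicity, read by neutral red uptake, with a stated time of 24 h, tested at 7.8 uM; a lower number here means a weaker effect, a higher number a stronger effect of the compound at the concentration tested:

Compound 1 `c1csc(CNc2ncnc3c2ncn3C2CCCO2)c1` gives 103%
Compound 2 `OCc1ccc(CNc2ncnc3c2ncn3C2CCCO2)o1` gives 105%
Compound 3 `Clc1nc(NCc2ccco2)c2ncn(C3CCCO3)c2n1` gives 104%

Compound 3 holds the second highest of the three numbers, yet the gaps to compound 1 and to compound 2 are both within the scatter. Compound 4 `Clc1nc(NCC2CCCO2)c2ncn(C3CCCO3)c2n1` differs from compound 3 by oxolan-2-yl in place of furan-2-yl on a saturated chain carbon bound to a nitrogen on an aromatic ring. Among the measured compounds shown here, the one measured step, a number 2 percentage points higher from compound 1 to compound 2 (within the scatter), also exchanges the group on a saturated chain carbon bound to a nitrogen on an aromatic ring, and it stayed within the scatter; no measured step exchanges an aromatic ring for a non-aromatic one. With all three numbers so close, the step to compound 4 is expected to be a number 1 percentage points lower from compound 3 to compound 4 (within the scatter), none beyond the scatter. Compound 4 is therefore estimated at 103%, within a range from 94% to 112%.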

Compound 4, a percentage reported as activity, at one concentration (the size of the read-out at that concentration, not a potency): 103%
The estimate for compound 4 equals the measured number at the digits printed; low and high end bracket the measured number.
By their numbers in this assay, from the lowest: compounds 1, 4, 3 and 2 (each within the scatter of the next).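

In this assay, the exchange of an aromatic ring for a non-aromatic one on a saturated chain carbon bound to a nitrogen on an aromatic ring gives a number 1 percentage points lower from compound 3 to compound 4 (within the scatter) and thus stays within the scatter. At this place and concentration, the read-out does not separate furan-2-yl from oxolan-2-yl, so ring aromaticity leaves no measurable mark here. Nothing available explains this result. As far as these compounds go, whether an amine or a carboxylic acid in place of oxolan-2-yl, or a longer chain at this place, would shift the read-out beyond the scatter remains open.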